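The source may report more compounds than this note shows. Statements on the series, on what has been measured and on what is new or still open speak of the compounds shown alone.

Measured in a functional assay on cells (T-cell line, Homo sapiens) for inhibition; a lower number here means a stronger inhibitor, a higher number a weaker inhibitor:
- compound 1 `CCCCN1CCC(COC(c2ccccc2)c2ccccc2)CC1`: 14000 nM
- compound 2 `CCCCCCCN1CCC(COC(c2ccccc2)c2ccccc2)CC1`: 500 nM
- compound 3 `CCCCCCCCCN1CCC(COC(c2ccccc2)c2ccccc2)CC1`: 700 nM

Compound 3 stands well away from the weak end of this short series, with a 20-fold lower number from compound 1 to compound 3 (1.30 log units; beyond the scatter). It cannot be told apart from its nearest neighbour, with a 1.4-fold higher number from compound 2 to compound 3 (0.15 log units; within the scatter).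

Compound 4 `CCCCCCCCCCN1CCC(COC(c2ccccc2)c2ccccc2)CC1` differs from compound 3 by a single change: methyl in place of hydrogen on a saturated chain carbon, nine bonds along the chain from an amine nitrogen in a ring. Three measured steps extend the same chain. The first two start from compound 1 and are large, with a 28-fold lower number from compound 1 to compound 2 (1.45 log units; beyond the scatter) alongside the step to compound 3 already given. Among the measured compounds shown here, the closest precedent, however, is the ethyl addition further out on the chain, which produced no change beyond the scatter. That step lies nearest in place and kind to the methyl addition, so it carries the most weight, and no step beyond the scatter is expected in this assay. The expected step is a 1.1-fold higher number from compound 3 to compound 4 (0.06 log units; within the scatter). For compound 4 the estimated value is 800 nM, with an expected range of 350 nM to 2000 nM.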

Compound 4, half-maximal inhibitory concentration: 2600 nM
Beside the measured number, compound 4's estimate is 3.3-fold (0.51 log units) below it; the whole stated range lies below it.
By their numbers in this assay, from the lowest: compounds 2 and 3 (each within the scatter of the next); then compound 4; then compound 1.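

In this assay, the methyl addition nine bonds along the chain from an amine nitrogen in a ring gives a 3.7-fold higher number from compound 3 to compound 4 (0.57 log units; beyond the scatter), the first step among these chain extensions that raises the number beyond the scatter. The gain made by the longer chains is thus partly lost, with a 5.2-fold higher number from compound 2 to compound 4 (0.72 log units; beyond the scatter), although the number stays on the stronger side of the shortest chain, with a 5.4-fold lower number from compound 1 to compound 4 (0.73 log units; beyond the scatter), so chain length does not act in one direction across the four compounds. No measurement here bears on the reason for this reversal.

The compounds shown leave open whether a longer chain would raise the number further. They also leave open whether a hydroxyl group or a phenyl ring on this chain would follow the methyl addition.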